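Aryl amine swap on the shared core

This account rests on a few compounds, and the source may have more. Where it says the series, first, only, none or still open, it means among the compounds named here.

Compound 2 `FC(F)(F)c1ccc(CSc2nc(Nc3cccc(Br)c3)c3ccccc3n2)cc1` stands highest of the two numbers in a functional assay on MGC-803 cells (Homo sapiens) for cytotoxicity, read by MTT assay, with a stated time of 72 h (a higher number here means a weaker inhibitor, a lower number a stronger inhibitor), where compound 2 gives 23700 nM. Its nearest neighbour is compound 1 `FC(F)(F)c1ccc(CSc2nc(N3CCCCC3)c3ccccc3n2)cc1`, which in this assay gives 18600 nM; the step of a 1.3-fold higher number from compound 1 to compound 2 (0.11 log units; within the scatter) lies within the scatter, so the two values show no order.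

Compound 3 `COc1ccc(Nc2nc(SCc3ccc(C(F)(F)F)cc3)nc3ccccc23)c(OC)c1` differs from compound 2 by 2,4-dimethoxyphenyl in place of 3-bromophenyl on a nitrogen on an aromatic ring. Within the data shown here, no measured step changes the group on that nitrogen while keeping the arylamino link; the only step on hand, a 1.3-fold higher number from compound 1 to compound 2 (0.11 log units; within the scatter), exchanges the whole substituent and was within the scatter. Nothing here points to a move beyond the scatter in either direction. Compound 3 is therefore expected to give 21000 nM in this assay, with a range from 8000 nM to 55000 nM. That corresponds to an expected step of a 1.1-fold lower number from compound 2 to compound 3 (0.05 log units; within the scatter), within the scatter.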

Compound 3, half-maximal inhibitory concentration: > 50000 nM
Compound 3: no number, only a limit (the forecaster's own chance of this, stated with the estimate: 10%); middle value at least 2.3-fold (0.37 log units) from the limit.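

The group on a nitrogen on an aromatic ring is not indifferent in this assay: the earlier pair showed no separation, but 2,4-dimethoxyphenyl in place of 3-bromophenyl gives an at least 2.1-fold higher number from compound 2 to compound 3 (0.32 log units; beyond the scatter). Against the piperidin-1-yl compound, the change to (2,4-dimethoxyphenyl)amino likewise gives an at least 2.6-fold higher number from compound 1 to compound 3 (0.42 log units; beyond the scatter), so an arylamino link alone does not set the level, and the aryl group on it counts. Compound 3 gives > 50000 nM, which is a limit and not a number, so both steps are lower bounds only: the limit of > 50000 nM in this assay, at which 1 of the 3 values shown sits.

Going by these compounds, whether the step belongs to the two methoxy groups together or to one of them remains open. A plain phenyl or a single methoxy on the phenyl could show whether such compounds stay with compound 2 or go with compound 3.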